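Benzoxazole thioether amides: mouse microsomal clearance notes

This account rests on a few compounds, and the source may have more. Where it says the series, first, only, none or still open, it means among the compounds named here.

Measured so far:
compound 1 `O=C(CCSc1nc2cc(Cl)ccc2o1)N1CCS(=O)(=O)C1` — 8.9 mL/min/g
compound 2 `COc1ccc2oc(SCCC(=O)N3CCCC3)nc2c1` — 198 mL/min/g

In an ADME assay on microsomes from liver (Mus musculus) for metabolic stability, read by LC-MS, using NADPH, with a stated time of 45 min, tested at 0.5 uM (a higher number here means faster removal of the compound, a lower number slower removal), compound 1 gives 8.9 mL/min/g, the lowest of the two numbers in hand. Compound 2 gives 198 mL/min/g in this assay, a gap from compound 1 that lies beyond the usual scatter. For the measured compounds named here, no pair differing in only one place has been measured, so no single-change step is known.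

Compound 3 `O=C(CCSc1nc2cc(Cl)ccc2o1)N1CCC1` is the next to be measured in this assay. It differs from compound 1 in one place: azetidin-1-yl in place of 1,1-dioxo-1,3-thiazolidin-3-yl on a carbonyl carbon. Going by the values given here, with only two numbers in hand, the direction of this change rests on the fact that compound 2, carrying a saturated ring amide of its own, gives 198 mL/min/g. The step of a 6.7-fold higher number from compound 1 to compound 3 (0.83 log units; beyond the scatter) is therefore expected to be upward and beyond the scatter. Compound 3 is estimated at 60 mL/min/g, within a range from 20 mL/min/g to 180 mL/min/g.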

Compound 3, intrinsic clearance in a liver preparation (reported as CLH), per the amount of preparation that the assay uses: 17.9 mL/min/g
The estimate for compound 3 lay 3.4-fold (0.53 log units) above the measured number, outside the stated range (below it).
By their numbers in this assay, from the lowest: compounds 1 and 3 (each within the scatter of the next); then compound 2.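

In this assay, azetidin-1-yl in place of 1,1-dioxo-1,3-thiazolidin-3-yl on a carbonyl carbon gives a 2.0-fold higher number from compound 1 to compound 3 (0.30 log units; within the scatter), so the two rings cannot be told apart at this position, even though the hydrogen-bond acceptors of the group that leaves are absent from the group that enters. A small saturated ring amide at this position therefore does not by itself bring the high number of compound 2, which differs from compound 1 and compound 3 in more than one place. Nothing in hand accounts for this result.

From the compounds shown here alone, how far the tolerance at this carbonyl carbon extends remains open, for example to a morpholin-4-yl ring or an open-chain dimethylamino amide. Also open, going by these compounds, is how much of the number for compound 2 belongs to its amide ring and how much to the methoxy group on its core.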